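This account rests on a few compounds, and the source may have more. Where it says the series, first, only, none or still open, it means among the compounds named here.

Of the compounds shown here, three of the shared core have been tested in a functional assay on BGC-823 cells (Homo sapiens) for cytotoxicity, read by CCK-8 assay, with a stated time of 24 h (a higher number here means a weaker inhibitor, a lower number a stronger inhibitor), and none of them gave a number. Compound 1 `C=C1CCC(c2csc(/C=C(\C)C(N)=O)c2)CC1` in this assay gives > 50000 nM, which is a limit of the assay rather than a measured value. Compound 2 `C/C(=C\c1cc(-c2cccnc2)co1)C(N)=O` in this assay gives > 50000 nM, again a limit. Compound 3 `C/C(=C\c1cc(-c2ccc(C)nc2)co1)C(N)=O` carries a methyl on the six-membered ring where compound 2 carries a hydrogen. In this assay compound 3 gives > 50000 nM, also a limit. Among the compounds with values here, compound 3 therefore stands where every compound tested so far stands: at the edge of what this assay can report, with no value to rank it against the others. Within the data shown here, the one step between measured compounds, from compound 2 to compound 3, is a step that the two limits leave unreadable from compound 2 to compound 3, and its size cannot be read because of the limit of > 50000 nM in this assay, at which 3 of the 3 values shown sit.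

Compound 4 `C/C(=C\c1cc(-c2ccc(F)nc2)co1)C(N)=O` is the next compound. It differs from compound 3 by fluoro in place of methyl on an aromatic carbon. Among the measured compounds shown here, no measured step shows what a change at this position does to this assay, and the only neighbouring step, the one from compound 2 to compound 3, is unreadable. The expected step is therefore a step that the limit leaves unreadable from compound 3 to compound 4, with no direction that the data support. Compound 4 is estimated to give 70000 nM in this assay, most likely again reported as a limit, with a range from 20000 nM to 250000 nM.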

Compound 4, half-maximal inhibitory concentration: > 50000 nM
Compound 4 gave a limit, no number; the forecaster's own chance of this, stated with the estimate: 85%; the middle value lies beyond the limit too.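

In this assay compound 4 gives > 50000 nM, again a limit and not a number. The steps to compound 4 from compound 2 and compound 3 therefore cannot be read, because all the compounds end at the same edge: the limit of > 50000 nM in this assay, at which 4 of the 4 values shown sit. The compounds shown leave open whether hydrogen, methyl or fluoro at this aromatic carbon changes the result at all.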